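Methoxy count on the ester aryl ring, step to compound 4

This account rests on a few compounds, and the source may have more. Where it says the series, first, only, none or still open, it means among the compounds named here.

Three esters of the shared core carry a methoxylated benzoyl group. Compound 1 `COC(=O)/C(=C\c1ccc(OC(=O)c2cccc(OC)c2)cc1)Sc1ccnc2cc(Cl)ccc12` gives 25500 nM in a functional assay on HL-60 cells (Homo sapiens) for cytotoxicity, read by MTT assay, with a stated time of 24 h; on this read-out higher numbers stand for weaker inhibition and lower numbers for stronger inhibition. Compound 2 `COC(=O)/C(=C\c1ccc(OC(=O)c2ccc(OC)c(OC)c2)cc1)Sc1ccnc2cc(Cl)ccc12` gives 5290 nM in this assay, and compound 3 `COC(=O)/C(=C\c1ccc(OC(=O)c2ccc(OC)cc2OC)cc1)Sc1ccnc2cc(Cl)ccc12` gives 7640 nM. On these numbers compound 3 stands second highest of the three: its nearest neighbour is compound 2, a gap that lies within the scatter, while the step of a 3.3-fold lower number from compound 1 to compound 3 (0.52 log units; beyond the scatter) lies beyond it.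

Compound 4 `COC(=O)/C(=C\c1ccc(OC(=O)c2cc(OC)cc(OC)c2OC)cc1)Sc1ccnc2cc(Cl)ccc12` is not yet measured. Its change from compound 3 is 2,3,5-trimethoxyphenyl in place of 2,4-dimethoxyphenyl on a carbonyl carbon; the group sits on a carbonyl carbon whose other neighbour is oxygen next to a carbonyl group.

Going by the values given here, two measured steps bear on this. The step of a 4.8-fold lower number from compound 1 to compound 2 (0.68 log units; beyond the scatter) shows that one added methoxy gave a modest lowering of the number. The step of a 1.4-fold higher number from compound 2 to compound 3 (0.16 log units; within the scatter) shows that moving methoxy groups about the ring, at fixed count, changed nothing beyond the scatter. Adding a third methoxy while rearranging is therefore expected to give at most a modest lowering, with no change beyond the scatter also plausible: the expected step is a 1.5-fold lower number from compound 3 to compound 4 (0.18 log units; within the scatter).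

Compound 4 is estimated at 5000 nM in this assay, within the range 2000 nM to 15000 nM.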

Compound 4, half-maximal inhibitory concentration: 10700 nM
Compound 4: the middle estimate sits 2.1-fold (0.33 log units) below what was measured; low and high end bracket the measured number.
By their numbers in this assay, from the lowest: compounds 2, 3 and 4 (each within the scatter of the next, the first and the last beyond it); then compound 1.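

In this assay, adding methoxy to the ester aryl ring no longer goes with a lower number once the ring carries the 2,3,5-trimethoxyphenyl group: a 1.4-fold higher number from compound 3 to compound 4 (0.15 log units; within the scatter) gives no readable gain over the 2,4-dimethoxyphenyl ester, and a 2.0-fold higher number from compound 2 to compound 4 (0.31 log units; beyond the scatter) runs against the count of methoxy groups. The link between more methoxy groups and a lower number seen with compound 2 and compound 3 therefore does not extend to compound 4, although a 2.4-fold lower number from compound 1 to compound 4 (0.38 log units; beyond the scatter) shows that the trimethoxyphenyl ester still keeps part of the advantage over the 3-methoxyphenyl ester. No supporting measurement is available to explain this turn at the carbonyl carbon.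

Count and arrangement change together in these steps, so the compounds shown cannot separate them, and it remains open how the 3,4,5-trimethoxyphenyl group would read in this assay. Also open, as far as these compounds go, is whether a hydroxy or dimethylamino group on the same ring, or a carboxylic acid in place of the methyl ester, would keep numbers in this range.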